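The compounds below may be only part of what the source reports. "The series", "measured", "known", "first", "only" and "open" are said of these compounds alone.

Measured so far in a functional assay on HeLa cells (Homo sapiens) for antiproliferative activity, read by MTT assay, with a stated time of 72 h; a higher number here means a weaker inhibitor, a lower number a stronger inhibitor:
compound 1 `CCNC(=O)c1cc(Oc2ccc(NC(=O)c3nn(-c4ccccc4OC(F)(F)F)c(=O)cc3C)cc2)ccn1`: 3990 nM
compound 2 `CCNC(=O)c1cc(Oc2ccc(NC(=O)c3nn(-c4ccc(C)cc4)c(=O)cc3C)cc2)ccn1`: 10700 nM

Of these two numbers, compound 2 holds the higher, at 10700 nM. Compound 3 `CCNC(=O)c1cc(Oc2ccc(NC(=O)c3nn(-c4cccc(C(F)(F)F)c4)c(=O)cc3C)cc2)ccn1` keeps the shared core and alters one group: 3-(trifluoromethyl)phenyl in place of 4-methylphenyl on an aromatic nitrogen. In words, 3-(trifluoromethyl)phenyl replaces 4-methylphenyl on an aromatic nitrogen.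

Among the compounds with values here, only one measured step bears on this change, at the same place: a 2.7-fold higher number from compound 1 to compound 2 (0.43 log units; beyond the scatter). It is modest and beyond the scatter. It involves a different incoming group at a different ring position, so it gives only a loose guide. With compound 1 at 3990 nM, a fluorinated group at this place has so far given the lower number, though this rests on a single pair. The expected step is of similar size, toward a lower number: a 2.1-fold lower number from compound 2 to compound 3 (0.33 log units; beyond the scatter). The estimate for compound 3 is 5000 nM, with an expected range of 2000 nM to 12000 nM.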

Compound 3, half-maximal inhibitory concentration: 10700 nM
Compound 3: middle estimate off by 2.1-fold (0.33 log units), on the low side; the range from low to high includes it.
By their numbers in this assay, from the lowest: compound 1; then compounds 2 and 3 (each within the scatter of the next).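

In this assay, 3-(trifluoromethyl)phenyl in place of 4-methylphenyl gives no change at the digits printed from compound 2 to compound 3 (within the scatter), so a fluorinated group at this place does not by itself lower the number. Replacing 2-(trifluoromethoxy)phenyl with 3-(trifluoromethyl)phenyl gives a 2.7-fold higher number from compound 1 to compound 3 (0.43 log units; beyond the scatter), which leaves the lower number tied to the 2-(trifluoromethoxy)phenyl of compound 1 rather than to fluorinated groups as a class, with compound 3 as the fluorinated case against that broader reading. No measurement bears on why these aryl groups differ or match.

From the compounds shown here alone, it remains open whether the lower number of compound 1 follows the trifluoromethoxy group itself or its ring position, a question that 3-(trifluoromethoxy)phenyl and 2-(trifluoromethyl)phenyl would address. Going by these compounds, the reading for a phenyl carrying an amine or a carboxylic acid at this place also remains open.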